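Swapping the chain substituent on the shared core

A few compounds are considered here, and "the series" means these few. Any claim that something is new, unique, unknown or untested is made for them only; others in the source may bear on it.

Compound 1 `C#CCCCn1c(Cc2cc(OC)c(OC)c(OC)c2)nc2c(N)ncnc21`, compound 2 `CCCCn1c(Cc2cc(OC)c(OC)c(OC)c2Br)nc2c(N)ncnc21` and compound 3 `CCCCn1c(Cc2cc(OC)c(OC)c(OC)c2Cl)nc2c(N)ncnc21` share a core and differ in the substituent pattern around it. In a functional assay on MCF7 cells (Homo sapiens) for antiproliferative activity (on this read-out lower numbers stand for stronger inhibition and higher numbers for weaker inhibition), compound 1 gives 24000 nM, compound 2 gives 25100 nM and compound 3 gives 19100 nM. Compound 1 thus stands second highest of the three numbers, but all three lie within the scatter of one another, so no order among them can be read. The only single-point step shown, a 1.3-fold lower number from compound 2 to compound 3 (0.12 log units; within the scatter), concerns a halogen on an aromatic carbon and says nothing about the chain carrying the triple bond.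

Compound 4 `COc1cc(Cc2nc3c(N)ncnc3n2CCOC(C)C)cc(OC)c1OC` differs from compound 1 in that chain: isopropoxy in place of propargyl on a saturated chain carbon, two bonds along the chain from an aromatic nitrogen. No measured pair touches this part of the molecule, so there is no step to lean on, and the one step shown stayed within the scatter. The account therefore expects compound 4 to land near compound 1, with no change at the digits printed from compound 1 to compound 4 (within the scatter) amounting to no change beyond the scatter, and estimates for compound 4 a value of 24000 nM in the range 9000 nM to 60000 nM.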

Compound 4, half-maximal inhibitory concentration: 38900 nM
Beside the measured number, compound 4's estimate is 1.6-fold (0.21 log units) below it; the measured number falls inside the stated range.
By their numbers in this assay, from the lowest: compounds 3, 1, 2 and 4 (each within the scatter of the next, the first and the last beyond it).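

In this assay, among the compounds shown here, putting isopropoxy in place of propargyl on a saturated chain carbon, two bonds along the chain from an aromatic nitrogen, gives a 1.6-fold higher number from compound 1 to compound 4 (0.21 log units; within the scatter), the first reading at this position. The triple bond leaves the chain and an oxygen enters it, yet the two numbers stay within the scatter of each other, so this one exchange shows no effect on the read-out that can be told apart from repeat variation. Nothing measured here speaks to why the number responds as it does at this position.

On these data alone, whether an amine, a carboxylic acid or a longer chain in this place would give a number beyond the scatter remains open. Also open, as far as these compounds go, is whether the isopropoxy chain would read the same alongside the bromo or chloro substituents carried by compound 2 and compound 3.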